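A few compounds are considered here, and "the series" means these few. Any claim that something is new, unique, unknown or untested is made for them only; others in the source may bear on it.

Measured so far in an in vitro functional assay on HEK293-A cells for positive allosteric modulation of metabotropic glutamate receptor 5 (Homo sapiens), read by fluorescence and calcium flux, with a stated time of 140 s; a lower number here means that less compound is needed, a higher number that more compound is needed for the effect:
compound 1, `O=C(C1CCCC1)N1CCCC1c1nc(-c2cccc(F)c2)no1`: 1000 nM
compound 2, `O=C(C1CCCCC1)N1CCCC1c1nc(-c2cccc(F)c2)no1`: 10000 nM
compound 3, `O=C(c1cccc(F)c1)N1CCCC1c1nc(-c2cccc(F)c2)no1`: 2600 nM

Compound 3 stands second highest of the three numbers in this assay: compound 1 sits nearest, compound 2 furthest, and the two steps that reach compound 3 are a 2.6-fold higher number from compound 1 to compound 3 (0.41 log units; beyond the scatter) and a 3.8-fold lower number from compound 2 to compound 3 (0.59 log units; beyond the scatter). Within the data shown here, the third step, a 10-fold higher number from compound 1 to compound 2 (1.00 log units; beyond the scatter), is the only one between two saturated rings on the carbonyl carbon.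

Compound 4, `O=C(c1ccc(F)cc1)N1CCCC1c1nc(-c2cccc(F)c2)no1`, differs from compound 3 in one place: 4-fluorophenyl in place of 3-fluorophenyl on a carbonyl carbon. Among the measured compounds shown here, every measured step at this carbonyl carbon exchanges one whole ring for another ring of a different kind; none moves the fluorine within an aromatic ring, so no step bears directly on this change. The two steps that do touch this position were modest, and a shift of a substituent around the same ring is expected to do less than a change of ring type. The step from compound 3 to compound 4 is therefore expected to stay within the scatter, with no firm direction, as no change at the digits printed from compound 3 to compound 4 (within the scatter). For compound 4 the estimate in this assay is 2600 nM, within a range of 900 nM to 7500 nM.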

Compound 4, half-maximal effective concentration: 3600 nM
Compound 4: middle estimate off by 1.4-fold (0.14 log units), on the low side, within the range that was stated.
By their numbers in this assay, from the lowest: compound 1; then compounds 3 and 4 (each within the scatter of the next); then compound 2.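

Exchanging 3-fluorophenyl for 4-fluorophenyl on the carbonyl carbon gives a step within the scatter in this assay (a 1.4-fold higher number from compound 3 to compound 4 (0.14 log units; within the scatter)), so for these two fluorophenyl groups the place of the fluorine on the ring makes no readable difference, whereas the exchanges of whole rings at this position do. Compound 4 also repeats the standing of compound 3 against the saturated rings: both new steps lie beyond the scatter (a 2.8-fold lower number from compound 2 to compound 4 (0.44 log units; beyond the scatter); a 3.6-fold higher number from compound 1 to compound 4 (0.56 log units; beyond the scatter)), which places both fluorophenyl amides between the cyclohexyl and cyclopentyl amides. Nothing available accounts for this order.

As far as these compounds go, it remains open whether the phenyl ring tolerates anything other than fluorine, such as chlorine, methoxy or nitrile, and what unsubstituted phenyl would give. Cyclobutyl would test whether the cyclopentyl-to-cyclohexyl trend extends to smaller saturated rings.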